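The source may hold more compounds than are shown below. What is called first, only, known or untested is meant among the compounds shown, and "the series" means these compounds.

Working notes on the series

Compound 1 `N#Cc1c(-c2ccc(Cl)cc2)nc(SCC(=O)Nn2c(COc3ccc(Cl)cc3Cl)nc3ccccc3c2=O)n(Cc2ccccc2)c1=O` carries a 4-chlorophenyl group on the shared core. In a functional assay on the whole organism (strain albino) for inhibition, with Rattus norvegicus as the target, read by paw edema, with a stated time of 1 h, at a dose of 100 mg/kg by the oral route (a lower number here means less inhibition, a higher number more inhibition at the dose given (going by the name of the read-out)), compound 1 gives 72.7%. Compound 2 `N#Cc1c(-c2ccc(O)cc2)nc(SCC(=O)Nn2c(COc3ccc(Cl)cc3Cl)nc3ccccc3c2=O)n(Cc2ccccc2)c1=O` differs from it in one place, (hydroxy in place of chloro on an aromatic carbon), and in this assay compound 2 gives 54.6%. For the measured compounds named here, the step of a number 18.1 percentage points lower from compound 1 to compound 2 (beyond the scatter) is the only measured step of this kind so far.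

Compound 3 `N#Cc1c(Nc2ccc(Cl)cc2)nc(SCC(=O)Nn2c(COc3ccc(Cl)cc3Cl)nc3ccccc3c2=O)nc1-c1ccc(Cl)cc1` has a core that differs from that of compound 1 in more than one place, so the difference between the two cores is not broken down here. In this assay compound 3 gives 54.6%, level with compound 2 at the digits printed and the lowest of the three numbers together with compound 2; against compound 1 the two values show compound 3 lower.

Compound 4 `N#Cc1c(Nc2ccc(O)cc2)nc(SCC(=O)Nn2c(COc3ccc(Cl)cc3Cl)nc3ccccc3c2=O)nc1-c1ccc(Cl)cc1` is not yet measured. It differs from compound 3 by hydroxy in place of chloro on an aromatic carbon, the same change that was made from compound 1 to compound 2, with the place described in the same words; cut one bond further out it reads (4-chlorophenyl)amino to (4-hydroxyphenyl)amino rather than 4-chlorophenyl to 4-hydroxyphenyl. Going by the values given here, from compound 3 to compound 4 a step of about a number 14.6 percentage points lower from compound 3 to compound 4 (beyond the scatter) is expected, resting on the single earlier step of a number 18.1 percentage points lower from compound 1 to compound 2 (beyond the scatter) and on the assumption that it carries over to a different core, which is not established by any second pair. Compound 4 is therefore expected to give about 40% in this assay, most likely between 25% and 58%.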

Compound 4, a percentage reported as inhibition, in the whole organism at one dose (the size of the read-out at that dose, not a potency): 90.9%
Estimate against measurement, compound 4: 50.9 percentage points below; the measured number lies above the stated range.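

On the core of compound 3, hydroxy in place of chloro on an aromatic carbon gives in this assay a result that runs the other way from the earlier pair, with a number 36.3 percentage points higher from compound 3 to compound 4 (beyond the scatter) as the step on this core. What the two pairs do not show is which feature of the cores goes with the reversal, since the cores differ in more than one place and the change sits on a (4-chlorophenyl)amino group in one pair and on a 4-chlorophenyl group in the other; both readings also come from a single dose and a single time, and they give the size of the read-out there, not a potency. For this series, the step measured on one core therefore gives neither the size nor the direction of the step on the other, and the two pairs are all that this rests on: the same change on two cores in this assay, a number 18.1 percentage points lower (beyond the scatter) from compound 1 to compound 2 and a number 36.3 percentage points higher (beyond the scatter) from compound 3 to compound 4, 54.4 percentage points apart, beyond the scatter of two such steps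

The compounds shown leave open whether the amino link or another part of the core decides the direction of the step, which would take pairs on cores that differ in one place only. Also open, on these data alone, is how other groups in the same place would read on each core, such as methoxy, an amine or a carboxylic acid.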